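The source may hold more compounds than are shown below. What is called first, only, known or untested is meant among the compounds shown, and "the series" means these compounds.

Measured so far in a functional assay on SW480 cells (Homo sapiens) for cytotoxicity, read by MTT assay, with a stated time of 48 h; a higher number here means a weaker inhibitor, a lower number a stronger inhibitor:
compound 1 `O=c1ccoc2cc(OCc3cn(Cc4ccccc4Br)nn3)ccc12` gives > 100000 nM, a limit of the assay.
compound 2 `O=c1ccoc2cc(OCc3cn(Cc4ccc(Cl)cc4Cl)nn3)ccc12` gives > 100000 nM, also a limit.
compound 3 `C#CCOc1ccc2c(=O)ccoc2c1` gives > 100000 nM, also a limit.

For the measured compounds named here, compound 1 therefore stands only at a limit in this assay, with no number of its own, and the same holds for every other value of the series so far; (the limit of > 100000 nM in this assay, at which 3 of the 3 values shown sit). Going by the values given here, the single computed step, a step that the two limits leave unreadable from compound 1 to compound 2, is unreadable between two limits, so it tells nothing about the size of any change on that position.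

The next compound, compound 4 `O=c1ccoc2cc(OCc3cn(Cc4cccc([N+](=O)[O-])c4)nn3)ccc12`, differs from compound 1 in one place: 3-nitrophenyl in place of 2-bromophenyl on a saturated chain carbon bound to an aromatic nitrogen. Among the compounds with values here, no measured step bears on this change in a readable way, and the series so far gives no instance of a measurable value at all. The expectation is therefore that compound 4 shows no step beyond the scatter in this assay, which means an expected step that the limit leaves unreadable from compound 1 to compound 4. Compound 4 is estimated at 150000 nM, in a range from 40000 nM to 600000 nM, most likely reported again as a limit.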

Compound 4, half-maximal inhibitory concentration: > 100000 nM
Compound 4: no number, only a limit; the forecaster's own chance of this, stated with the estimate: 85%; the middle value is on the limit's open side.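

In this assay compound 4 gives > 100000 nM, a limit and not a number. The steps from compound 1 and compound 2 to compound 4 cannot be read: the limit of > 100000 nM in this assay, at which 4 of the 4 values shown sit. The compounds shown leave open how any substituent on a saturated chain carbon bound to an aromatic nitrogen ranks by measured potency.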